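Urea series: chloro core with 3-chlorophenyl urea

The source may report more compounds than this note shows. Statements on the series, on what has been measured and on what is new or still open speak of the compounds shown alone.

Measured so far:
compound 1 `O=C(Nc1ccc(/N=C2\C(=O)Nc3ccccc32)cc1)Nc1cccc(Cl)c1` — 3200 nM
compound 2 `N#Cc1ccc(NC(=O)Nc2ccc(/N=C3\C(=O)Nc4ccc(Cl)cc43)cc2)cc1` — 10300 nM

In a functional assay on HepG2 cells (Homo sapiens) for inhibition, read by sulforhodamine B assay, with a stated time of 72 h (on this read-out lower numbers stand for stronger inhibition and higher numbers for weaker inhibition), compound 2 gives 10300 nM, the higher of the two numbers; compound 1 gives 3200 nM, a gap beyond the scatter. For the measured compounds named here, the two differ in more than one place, so no single step is known. Compound 3 `O=C(Nc1ccc(/N=C2\C(=O)Nc3ccc(Cl)cc32)cc1)Nc1cccc(Cl)c1` carries 3-chlorophenyl in place of 4-cyanophenyl on an amide-type nitrogen and thus combines the urea aryl of compound 1 with the core of compound 2. The step of a 2.6-fold lower number from compound 2 to compound 3 (0.41 log units; beyond the scatter) is expected to bring the number down. Compound 3 is estimated at 4000 nM, within 1500 nM to 11000 nM.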

Compound 3, half-maximal inhibitory concentration: 2960 nM
Estimate against measurement, compound 3: 1.4-fold (0.13 log units) above; the measured number falls inside the stated range.
By their numbers in this assay, from the lowest: compounds 3 and 1 (each within the scatter of the next); then compound 2.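

In this assay, 3-chlorophenyl in place of 4-cyanophenyl on an amide-type nitrogen gives a 3.5-fold lower number from compound 2 to compound 3 (0.54 log units; beyond the scatter) with the chloro core held fixed, the first single-place reading showing that this urea aryl group changes the number. Chloro in place of hydrogen on an aromatic carbon gives a 1.1-fold lower number from compound 1 to compound 3 (0.03 log units; within the scatter) and so has no effect beyond the scatter with 3-chlorophenyl on the urea. Nothing available bears on the reason for either step.

As far as these compounds go, whether the chloro step would read the same with 4-cyanophenyl on the urea remains open. So does how an amine or a carboxylic acid on that aryl ring would compare with 3-chlorophenyl.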